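This account rests on a few compounds, and the source may have more. Where it says the series, first, only, none or still open, it means among the compounds named here.

Measured compounds:
compound 1, `COc1cccc(/C=C/C(=O)c2ccc(OC)c3c2OC(C)(C)C=C3)c1`: in a functional assay on HepG2 cells (Homo sapiens) for antiproliferative activity, read by MTT assay, with a stated time of 24 h (on this read-out higher numbers stand for weaker inhibition and lower numbers for stronger inhibition), compound 1 gives > 10000 nM, which is a limit of the assay.
compound 2, `COc1ccc(/C=C/C(=O)c2ccc(OC)c3c2OC(C)(C)C=C3)c(F)c1`: in this assay compound 2 gives 7560 nM.
compound 3, `COc1ccc(C(=O)/C=C/c2ccc(-c3ccccc3)cc2)c2c1C=CC(C)(C)O2`: in this assay compound 3 gives > 10000 nM, which is a limit of the assay.

Compound 3 therefore stands at a limit rather than at a number; (the limit of > 10000 nM in this assay, at which 2 of the 3 values shown sit). Within the data shown here, only one step between two measured compounds exists, an at least 1.3-fold lower number from compound 1 to compound 2 (0.12 log units; that floor lies within the scatter), and it concerns the aryl group at the end of the chain, with a floor that lies within the scatter.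

Compound 4, `COc1ccc(C(=O)/C=C/c2ccc([N+](=O)[O-])cc2)c2c1C=CC(C)(C)O2`, differs from compound 3 by nitro in place of phenyl on an aromatic carbon. Among the measured compounds shown here, no measured step alters this position; the step from compound 1 to compound 2 replaces one chain aryl group with another and is within the scatter, so it gives no direction for the present change. With compound 3 at a limit, the expectation for compound 4 in this assay is no step beyond the scatter, in either direction, and a fair chance of another limit.

The expected value for compound 4 is 9000 nM, with a range from 3000 nM to 30000 nM. The expected step is an at least 1.1-fold lower number from compound 3 to compound 4 (0.04 log units; that floor lies within the scatter).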

Compound 4, half-maximal inhibitory concentration: 2610 nM
Compound 4: the middle estimate sits 3.4-fold (0.54 log units) above what was measured; the whole stated range lies above it.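

Among these compounds, at the ring position para to a large group, nitro in place of phenyl gives the first step that lies beyond the scatter: in this assay, the change gives an at least 3.8-fold lower number from compound 3 to compound 4 (0.58 log units; beyond the scatter). The other end groups give the same direction, with 4-nitrophenyl in place of 2-fluoro-4-methoxyphenyl giving a 2.9-fold lower number from compound 2 to compound 4 (0.46 log units; beyond the scatter) and 4-nitrophenyl in place of 3-methoxyphenyl giving an at least 3.8-fold lower number from compound 1 to compound 4 (0.58 log units; beyond the scatter), so compound 4 has the lowest number of the four and the aryl group at the end of the chain is shown to matter on this read-out. The steps that start from compound 1 and compound 3 are floors and not sizes, because both of these compounds stand at a limit: the limit of > 10000 nM in this assay, at which 2 of the 4 values shown sit.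

The compounds shown do not separate a contribution of nitro itself from the loss of phenyl, and an amine, a nitrile or a carboxylic acid at the same ring position would help to tell these two readings apart. Also open, on these data alone, is whether nitro would give a step of similar size with a methoxy or a fluorine on the same aryl group.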